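Swapping a Methyl for a Hydroxy on a Channel Agonist

The source may hold more compounds than are shown below. What is called first, only, known or untested is meant among the compounds shown, and "the series" means these compounds.

Of the compounds shown here, two have so far been measured in an assay on HEK293 cells for agonist activity at transient receptor potential cation channel subfamily M member 8 (Homo sapiens), read by fluorescence and calcium flux, with a stated time of 15 min; a higher number here means that more compound is needed for the effect, a lower number that less compound is needed. Compound 1 `CCc1ccc(OCC(=O)N(CC)Cc2cccs2)cc1` gives 67 nM in this assay, the higher of the two numbers. Compound 2 `Cc1ccc(OCC(=O)N(Cc2cccs2)c2ccn[nH]2)cc1` gives 0.2 nM in this assay, a far lower number, well beyond the usual scatter. Compound 3 `CCN(Cc1cccs1)C(=O)COc1ccc(CO)cc1` has not been measured; it differs from compound 1 by hydroxy in place of methyl on a saturated chain carbon bound to an aromatic carbon. Among the measured compounds shown here, no measured pair shows this change, so its effect is unknown here. The expected step is a 2.2-fold higher number from compound 1 to compound 3 (0.35 log units; beyond the scatter), modest and toward a higher number. Compound 3 is estimated at 150 nM in this assay, within a range from 30 nM to 800 nM.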

Compound 3, half-maximal effective concentration: 21900 nM
Compound 3: the middle estimate sits 150-fold (2.16 log units) below what was measured; the measured number lies above the stated range.
By their numbers in this assay, from the lowest: compound 2; then compound 1; then compound 3.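

The swap of hydroxy for methyl on a saturated chain carbon bound to an aromatic carbon, also readable as ethyl to hydroxymethyl, gives a 330-fold higher number from compound 1 to compound 3 (2.51 log units; beyond the scatter) in this assay. This small change, which adds 1 hydrogen-bond donor and 1 hydrogen-bond acceptor, is therefore far from neutral at this position. Nothing available accounts for a step of this size. From the compounds shown here alone, whether a methoxy group, an amine or a longer chain at this position would raise the number as much remains open. So does whether the same swap would act alike on compound 2.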